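Swapping the Aryl Ring on the Core Nitrogen

The compounds below may be only part of what the source reports. "The series", "measured", "known", "first", "only" and "open" are said of these compounds alone.

Of the compounds shown here, three in this set have been tested in a functional assay on CHO-K1 cells with Glucose-dependent insulinotropic receptor (Homo sapiens) as the target, read by a luciferase reporter, with a stated time of 5 h; a higher number here means a larger maximal response, a lower number a smaller maximal response. Compound 1 `CCSC(=O)N1CCC(Oc2ncnc3c2CCN3c2ccc(S(C)(=O)=O)cc2F)CC1` gives 128%, compound 2 `CC(C)OC(=O)N1CCC(Oc2nc(N)nc3c2CCN3c2ccc(S(C)(=O)=O)cc2F)CC1` gives 33%, and compound 3 `CC(C)OC(=O)N1CCC(Oc2ncnc3c2CCN3c2ccc(S(C)(=O)=O)nc2)CC1` gives 97%. On these numbers compound 3 stands second highest of the three: compound 1 lies above it, beyond the scatter, and compound 2 lies well below it, also beyond the scatter. Compound 1 and compound 3 differ in more than one place, so their gap cannot be tied to a single change.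

Compound 4 `CC(C)OC(=O)N1CCC(Oc2ncnc3c2CCN3c2ccc([S@@+](C)[O-])c(F)c2)CC1` has not yet been measured. It differs from compound 3 in one place: a group of 10 heavy atoms (7 carbon, 1 oxygen, 1 fluorine, 1 sulfur; one six-membered aromatic ring of carbon only) in place of a group of 10 heavy atoms (6 carbon, 1 nitrogen, 2 oxygen, 1 sulfur; one six-membered aromatic ring with 1 hetero atom), on a nitrogen on an aromatic ring in a ring The ring that leaves is the 6-(methylsulfonyl)pyridin-3-yl group; the ring that enters is a six-membered aromatic ring of carbon only carrying fluorine, oxygen and sulfur, with one defined stereocentre.

Within the data shown here, no measured pair isolates this change, so the expected size of the step rests on compound 3 alone. The expected step is a number 2 percentage points lower from compound 3 to compound 4 (within the scatter), none beyond the usual scatter in either direction. Compound 4 is estimated to give about 95% in this assay, with a range from 60% to 130%.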

Compound 4, largest response reached (reported as percent of maximum), in percent of the reference or control that the assay uses: 155%
Estimate against measurement, compound 4: 60 percentage points below; measured number above the stated range.
By their numbers in this assay, from the lowest: compound 2; then compound 3; then compound 1; then compound 4.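

The group on the ring nitrogen of the shared core clearly matters for the size of the response: the swap gives a number 58 percentage points higher from compound 3 to compound 4 (beyond the scatter) in this assay. This is the first step shown at this position, and the two groups have the same count of 10 heavy atoms, each built on a six-membered aromatic ring. Heavy-atom count alone therefore does not set the maximal response here, and no measurement shown bears on why the response rises.

The ring atoms, the fluorine and the sulfur group all change at once in this swap, and the compounds shown do not separate their contributions. Also open, from the compounds shown here alone, are the effect of the opposite stereocentre and how the response would move with an amine or a carboxylic acid on the ring in place of the sulfur group.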